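Reversing the nitrile: two fluorines on the aryl ring

The source may report more compounds than this note shows. Statements on the series, on what has been measured and on what is new or still open speak of the compounds shown alone.

Three analogues sharing one core have been measured in a functional assay on HEK293 cells with D(4) dopamine receptor (Homo sapiens) as the target, read by FLIPR; a lower number here means a smaller maximal response, a higher number a larger maximal response. Compound 1 `Cc1ccccc1/C(CCN1CCN(c2ccccn2)CC1)=N/O` gives 82%, compound 2 `O/N=C(\CCN1CCN(c2ccccn2)CC1)c1cccc(F)c1` gives 72%, and compound 3 `N#Cc1cccc(/C(CCN2CCN(c3ccccn3)CC2)=N/O)c1` gives 48%. Compound 3 stands lowest of the three: a number 24 percentage points lower from compound 2 to compound 3 (beyond the scatter) and a number 34 percentage points lower from compound 1 to compound 3 (beyond the scatter), whereas a number 10 percentage points lower from compound 1 to compound 2 (within the scatter). Compound 4 `O/N=C(\CCN1CCN(c2ccccn2)CC1)c1cc(F)cc(F)c1` is not yet measured; it carries 3,5-difluorophenyl in place of 3-cyanophenyl on a carbon with a double bond to nitrogen. Among the compounds with values here, the step from compound 2 to compound 3, which put cyano in place of fluoro, bears most directly on this change; the new change removes the cyano again and brings two fluorines, for which no measured pair exists. Compound 4 is therefore expected to give 68%, in a range from 50% to 85%. This estimate means a number 20 percentage points higher from compound 3 to compound 4 (beyond the scatter), expected to lie beyond the scatter.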

Compound 4, largest response reached (reported as efficacy), in percent of the reference or control that the assay uses: 74%
Estimate against measurement, compound 4: 6 percentage points below, and the stated range covers the measured number.
By their numbers in this assay, from the lowest: compound 3; then compounds 2, 4 and 1 (each within the scatter of the next).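

In this assay, the 3,5-difluorophenyl group brings back the response lost with the 3-cyanophenyl group, with a number 26 percentage points higher from compound 3 to compound 4 (beyond the scatter), so the low value goes with the nitrile and not with every substituted aryl ring here. The second fluoro adds little, with a number 2 percentage points higher from compound 2 to compound 4 (within the scatter), and the change from 2-methylphenyl also stays small, with a number 8 percentage points lower from compound 1 to compound 4 (within the scatter), leaving only compound 3 apart among the four. Nothing available explains why the nitrile stands apart. On these data alone, whether a methoxy group or an amine on the aryl ring would lower the response as the nitrile does remains open.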